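Purine benzamide series: cyclopentyl for dimethoxypropyl

This account rests on a few compounds, and the source may have more. Where it says the series, first, only, none or still open, it means among the compounds named here.

Measured compounds:
Compound 1 `Nc1ccccc1NC(=O)c1ccc(Cn2cnc3c(Nc4ccc(-c5ccccn5)cc4)nc(Cl)nc32)cc1` gives 73.7%.
Compound 2 `COC(CCn1cnc2c(NCc3ccc(C(=O)Nc4ccccc4N)cc3)nc(Cl)nc21)OC` gives 11.9%.
Compound 3 `CCCCn1cnc2c(Nc3ccccc3)nc(NCOCc3ccc(C(=O)Nc4ccccc4N)cc3)nc21` gives 74.9%.

In a functional assay on HCT-116 cells (Homo sapiens) for antiproliferative activity, read by CCK-8 assay, with a stated time of 72 h, tested at 8 uM (a lower number here means a weaker effect, a higher number a stronger effect of the compound at the concentration tested), compound 2 stands lowest of the three, with both compound 1 and compound 3 giving numbers beyond the scatter higher. Going by the values given here, neither of those two differs from compound 2 in a single place, so no step between measured compounds is available.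

Compound 4 `Nc1ccccc1NC(=O)c1ccc(CNc2nc(Cl)nc3c2ncn3C2CCCC2)cc1` differs from compound 2 by cyclopentyl in place of 3,3-dimethoxypropyl on an aromatic nitrogen. Among the compounds with values here, with no measured step of this kind, the size and direction of a number 23.1 percentage points higher from compound 2 to compound 4 (beyond the scatter) are expected rather than known; a moderate rise is estimated because compound 2 sits at 11.9% while the rest of the series lies far higher. Compound 4 is estimated at 35%, with a range from 10% to 65%.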

Compound 4, a percentage reported as inhibition, at one concentration (the size of the read-out at that concentration, not a potency): 80.6%
Compound 4: the middle estimate sits 45.6 percentage points below what was measured, and the stated range ends below it.
By their numbers in this assay, from the lowest: compound 2; then compounds 1, 3 and 4 (each within the scatter of the next).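

In this assay, the group on the aromatic nitrogen proves decisive for this pair: cyclopentyl in place of 3,3-dimethoxypropyl gives a number 68.7 percentage points higher from compound 2 to compound 4 (beyond the scatter) with the rest of the structure unchanged. Going by these compounds alone, this is the first single-place comparison, and it ties the low number of compound 2 to its 3,3-dimethoxypropyl group. No available data give a reason for the step.

Going by these compounds, it remains open whether the ring or the absence of oxygen matters more. A cyclohexyl ring or a 3-hydroxypropyl chain at this nitrogen would test how far the step extends.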